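The source may hold more compounds than are shown below. What is called first, only, known or untested is meant among the compounds shown, and "the series" means these compounds.

Measured so far:
- compound 1, `CCn1nc(C)c2c1CCN(C(C(=O)NC)c1ccccc1)C2CCc1cccc(C(F)(F)F)c1`: 7 nM
- compound 2, `CCn1nc(C)c2c1CCN(C(C(=O)NC)c1ccccc1)C2CCc1cccc(F)c1`: 10 nM

Both compounds were tested in a functional assay on CHO cells for antagonist activity at Orexin receptor type 2 (Homo sapiens), read by FLIPR and calcium flux; a higher number here means a weaker inhibitor, a lower number a stronger inhibitor. Compound 2 stands next to compound 1 on these numbers, and the two values are within the scatter of each other: the step of a 1.4-fold higher number from compound 1 to compound 2 (0.15 log units; within the scatter) is too small to count as a real change.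

Compound 3, `CCn1nc(C)c2c1CCN(C(C(=O)NC)c1ccccc1)C2CCc1ccc(C)cc1`, has not yet been measured. It differs from compound 2 only on the pendant aromatic ring: 4-methylphenyl in place of 3-fluorophenyl on a saturated chain carbon, two bonds along the chain from a saturated ring carbon.

Among the measured compounds shown here, the one measured step that bears on this change is the swap on the same ring, a 1.4-fold higher number from compound 1 to compound 2 (0.15 log units; within the scatter), which stayed within the scatter. On that basis no step beyond the scatter is expected in this assay from compound 2 to compound 3, and the step is estimated as a 1.2-fold higher number from compound 2 to compound 3 (0.08 log units; within the scatter). Compound 3 is therefore estimated at 12 nM, with a range of 4 nM to 40 nM.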

Compound 3, half-maximal inhibitory concentration: 6 nM
For compound 3 the middle estimate is 2.0-fold (0.30 log units) above the measured one; low and high end bracket the measured number.
By their numbers in this assay, from the lowest: compounds 3, 1 and 2 (each within the scatter of the next).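

Measured in this assay the swap of 3-fluorophenyl for 4-methylphenyl gives a 1.7-fold lower number from compound 2 to compound 3 (0.22 log units; within the scatter) and the swap of 3-(trifluoromethyl)phenyl for 4-methylphenyl gives a 1.2-fold lower number from compound 1 to compound 3 (0.07 log units; within the scatter) and so neither counts as a real change. The earlier pair varied only the group on the 3 place of the ring, whereas compound 3 shows that a ring of carbon only, with methyl named at the 4 place, also gives a number within the scatter of both. No measurement at hand offers an explanation for how close these numbers are.

Compound 3 alters the group and its place on the ring together, so these compounds cannot separate the two. On these data alone, whether an amine, a carboxylic acid or a longer chain in place of the 2-(4-methylphenyl)ethyl group would keep the number in this range remains open.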